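Working notes: methylamino in place of hydrogen on compound 2

A few compounds are considered here, and "the series" means these few. Any claim that something is new, unique, unknown or untested is made for them only; others in the source may bear on it.

- compound 1 `Nc1nc(Cl)c(-c2nc3ccccc3o2)c(N[C@@H]2C[C@H](CO)[C@@H](O)[C@H]2O)n1` gives 12000 nM
- compound 2 `Nc1nc(Cl)c(-c2nc3ccccc3s2)c(N[C@@H]2C[C@H](CO)[C@@H](O)[C@H]2O)n1` gives 14000 nM

In an ADME assay on cells (Homo sapiens) for cytotoxicity, read by polymerase chain reaction, with a stated time of 3 days (on this read-out lower numbers stand for higher toxicity in this test and higher numbers for lower toxicity in this test), compound 2 gives 14000 nM and sits within the scatter of compound 1 at 12000 nM on the two numbers available. Compound 3 `CNc1ccc2nc(-c3c(Cl)nc(N)nc3N[C@@H]3C[C@H](CO)[C@@H](O)[C@H]3O)sc2c1` differs from compound 2 by methylamino in place of hydrogen on an aromatic carbon. Within the data shown here, the only measured step is a 1.2-fold higher number from compound 1 to compound 2 (0.07 log units; within the scatter) and it lies within the scatter, but it concerns 1,3-benzothiazol-2-yl in place of 1,3-benzoxazol-2-yl and not this change. Among the measured compounds shown here, no measured step covers methylamino, so the expectation rests on compound 2 at 14000 nM with a wide margin. In this assay an expected 1.1-fold lower number from compound 2 to compound 3 (0.03 log units; within the scatter) means that no shift beyond the scatter is foreseen and no direction is favoured. Compound 3 is estimated at 13000 nM within a range of 4000 nM to 40000 nM on this read-out.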

Compound 3, half-maximal cytotoxic concentration: 6000 nM
Estimate against measurement, compound 3: 2.2-fold (0.34 log units) above; measured number inside the range.
By their numbers in this assay, from the lowest: compounds 3, 1 and 2 (each within the scatter of the next, the first and the last beyond it).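

In this assay, methylamino in place of hydrogen on an aromatic carbon of the six-membered aromatic ring of carbon only gives a 2.3-fold lower number from compound 2 to compound 3 (0.37 log units; beyond the scatter) and so shows that this position responds to substitution, whereas the change on the other side of the molecule, a 1.2-fold higher number from compound 1 to compound 2 (0.07 log units; within the scatter), does not move the number beyond the scatter. Since lower numbers stand for higher toxicity in this test, adding methylamino here goes with higher toxicity, although the step is modest and rests on one pair. Nothing available bears on the reason for this step.

Still open, as far as these compounds go, is whether the step is specific to methylamino, which an unsubstituted amine, dimethylamino or a methoxy group on the same carbon would test. Also open, from the compounds shown here alone, is whether methylamino on the same carbon of the 1,3-benzoxazol-2-yl group of compound 1 would give a step of similar size.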